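From ethyl to propyl on compound 2

The source may hold more compounds than are shown below. What is called first, only, known or untested is meant among the compounds shown, and "the series" means these compounds.

Compound 1 `Cc1ccc(C(=O)Nc2cccc(C(F)(F)F)c2)cc1-c1ccc2c(-c3cnn(C)c3)n[nH]c2c1` gives 65.7 nM
Compound 2 `CCn1cc(-c2n[nH]c3cc(-c4cc(C(=O)Nc5cccc(C(F)(F)F)c5)ccc4C)ccc23)cn1` gives 257 nM

In a functional assay on KG-1 cells (Homo sapiens) for antiproliferative activity, read by CCK-8 assay, with a stated time of 72 h (a higher number here means a weaker inhibitor, a lower number a stronger inhibitor), compound 2 stands at 257 nM, the higher of the two numbers, which makes it the weaker inhibitor of the pair. Compound 3 `CCCn1cc(-c2n[nH]c3cc(-c4cc(C(=O)Nc5cccc(C(F)(F)F)c5)ccc4C)ccc23)cn1` differs from it in one place: methyl in place of hydrogen on a saturated chain carbon, two bonds along the chain from an aromatic nitrogen. This is methyl in place of hydrogen on a saturated chain carbon, two bonds along the chain from an aromatic nitrogen, so ethyl becomes propyl. Among the measured compounds shown here, one measured step bears on this, the same swap made on the chain carbon bound to the aromatic nitrogen: a 3.9-fold higher number from compound 1 to compound 2 (0.59 log units; beyond the scatter). One step is thin evidence, so a further rise of similar or smaller size is expected, and the expected move is a 1.8-fold higher number from compound 2 to compound 3 (0.24 log units; within the scatter) in this assay. Compound 3 is estimated at 450 nM, with an expected range from 170 nM to 1200 nM.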

Compound 3, half-maximal inhibitory concentration: 358 nM
For compound 3 the middle estimate is 1.3-fold (0.10 log units) above the measured one; measured number inside the range.
By their numbers in this assay, from the lowest: compound 1; then compounds 2 and 3 (each within the scatter of the next).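

In this assay, replacing 1-ethyl-1H-pyrazol-4-yl with 1-propyl-1H-pyrazol-4-yl gives a 1.4-fold higher number from compound 2 to compound 3 (0.14 log units; within the scatter), so adding a methyl two bonds along the chain from the aromatic nitrogen produces no change that can be separated from ordinary measurement noise, whereas the methyl-to-ethyl change gave a 3.9-fold higher number from compound 1 to compound 2 (0.59 log units; beyond the scatter). Going from methyl straight to propyl gives a 5.4-fold higher number from compound 1 to compound 3 (0.74 log units; beyond the scatter), so among these three compounds the clear difference appears with the first added carbon and the second adds nothing measurable. Nothing available explains this behaviour of the chain.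

The compounds shown leave open how a butyl chain, a branched isopropyl group or a propyl chain ending in an amine would read in this assay. They also leave open whether the level seen for ethyl and propyl holds for longer chains.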